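This account rests on a few compounds, and the source may have more. Where it says the series, first, only, none or still open, it means among the compounds named here.

In a functional assay on L1210 cells (Mus musculus) for cytotoxicity, with a stated time of 48 h (a lower number here means a stronger inhibitor, a higher number a weaker inhibitor), compound 2, `O=c1oc2ccccc2cc1-c1cn2nc(Cc3ccc(Cl)cc3)sc2n1`, gives only a limit, > 10000 nM. Compound 1, `Clc1ccc(Cc2nn3cc(-c4ccc(Br)cc4)nc3s2)cc1`, likewise reaches only a limit in this assay, > 250000 nM. Compound 3, `Clc1ccc(Cc2nn3c(Br)c(-c4ccc(Cl)cc4Cl)nc3s2)cc1`, gives a number in this assay, 31000 nM. Compound 2 therefore stands among results of which two are limits, as the limit of > 10000 nM in this assay, at which 1 of the 3 values shown sits, and the limit of > 250000 nM in this assay, at which 1 of the 3 values shown sits, show, and only compound 3 offers a number. Compound 4, `O=c1oc2ccccc2cc1-c1nc2sc(Cc3ccc(Cl)cc3)nn2c1Br`, differs from compound 2 by bromo in place of hydrogen on an aromatic carbon. Among the measured compounds shown here, no pair of measured compounds isolates this change. The step that the limit leaves unreadable from compound 2 to compound 4 is expected to be small, no larger than the scatter, with weak inhibition remaining. Compound 4 is estimated at 20000 nM, within a range from 5000 nM to 80000 nM.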

Compound 4, half-maximal inhibitory concentration: 5200 nM
For compound 4 the middle estimate is 3.8-fold (0.59 log units) above the measured one; the range from low to high includes it.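

Among the compounds shown here, the pair of compound 2 and compound 4 is the first to isolate bromo in place of hydrogen on an aromatic carbon, and in this assay it gives an at least 1.9-fold lower number from compound 2 to compound 4 (0.28 log units; that floor lies within the scatter). The change therefore turns a limit into a number, but it is not shown to exceed the scatter. The true size of the step stays unreadable, since compound 2 gives only a limit: the limit of > 10000 nM in this assay, at which 1 of the 4 values shown sits.

As far as these compounds go, it remains open whether an amine or a carboxylic acid at this place would shift the number. Whether bromo has a comparable effect on the core of compound 1 is also unknown.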